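Notes on the amino substituent step from compound 1 to compound 4

The source may hold more compounds than are shown below. What is called first, only, known or untested is meant among the compounds shown, and "the series" means these compounds.

Measured in a functional assay on cells (Lymphocyte, Homo sapiens) for inhibition, read by flow cytometry, using a membrane potential dye, with a stated time of 16 h, tested at 100 nM (on this read-out lower numbers stand for a weaker effect and higher numbers for a stronger effect at the one concentration tested), so far:
compound 1 `CCCCCCCCCCCCCCCCc1nc(N2CCC2)c(C)c(C)c1O`: 54%
compound 2 `CCCCCCCCCCCCCCCCc1c(C)c(N2CCC2)nc(C)c1O`: 55%
compound 3 `CCCCCCCCCCCCCCCCCCCc1c(C)c(N(C)C)nc(C)c1O`: 23%

Compound 1 stands second highest of the three numbers. Compound 2 sits within the usual scatter of compound 1, so no order between the two is claimed. Among the compounds with values here, compound 3 lies beyond the scatter, clearly below compound 1, but compounds 1 and 3 differ in more than one place, so their two values show only that the compound carrying the dimethylamino group reads lower. Within the data shown here, no pair of measured compounds differs in one place; there is no measured step to lean on.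

Compound 4 `CCCCCCCCCCCCCCCCc1nc(N(C)C)c(C)c(C)c1O` is not yet measured. It differs from compound 1 by dimethylamino in place of azetidin-1-yl on an aromatic carbon. With compound 3 as the only dimethylamino-bearing reference at 23%, a downward step is expected, and compound 4 is estimated to give a number 14 percentage points lower from compound 1 to compound 4 (beyond the scatter) in this assay, a step of moderate size that may reach beyond the scatter. Compound 4 is expected to read about 40%, within a range of 20% to 60%.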

Compound 4, a percentage reported as activity, at one concentration (the size of the read-out at that concentration, not a potency): 67%
Estimate against measurement, compound 4: 27 percentage points below; measured number outside the range, above it.
By their numbers in this assay, from the lowest: compound 3; then compounds 1 and 2 (each within the scatter of the next); then compound 4.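

In this assay, within the data shown here, the one step readable at this position, on an aromatic carbon next to the ring nitrogen, is a number 13 percentage points higher from compound 1 to compound 4 (beyond the scatter), so on the core of compound 1 the azetidin-1-yl ring is not required for the effect. The dimethylamino group therefore does not by itself go with a low number: compound 4 carries it and gives 67%, while compound 3 differs from compound 4 in more than one place and cannot be set against it. Nothing measured here accounts for this step.

On these data alone, whether the same change gives a step of this direction on the core of compound 2 remains open. Also open, as far as these compounds go, is how diethylamino or pyrrolidin-1-yl would read at this position, and so whether the step follows the loss of the ring or the number of heavy atoms in the group.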